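This account rests on a few compounds, and the source may have more. Where it says the series, first, only, none or still open, it means among the compounds named here.

Measured so far:
Compound 1 `O=C(CSc1nncnc1-c1cccc2ccccc12)Nc1ccccc1Br` gives 87000 nM in an ADME assay on MT4 cells (Homo sapiens) for cytotoxicity, read by MTT assay; on this read-out higher numbers stand for lower toxicity in this test and lower numbers for higher toxicity in this test.
Compound 2 `Cc1ccc2sc(NC(=O)CSc3nncnc3-c3ccccc3Cl)nc2c1` gives 137000 nM in this assay.
Compound 3 `O=C(CSc1nncnc1-c1ccccc1Cl)Nc1ccc(Cl)cc1Cl` gives 51000 nM in this assay.

Among these three numbers compound 3 stands lowest. Its nearest neighbour is compound 1, whose value lies within the usual scatter of repeated measurements, so the two cannot be told apart on this read-out. Compound 2 is the furthest away, and its value does lie beyond the scatter, so compound 2 can be said to be less toxic in this assay than compound 3.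

Compound 4 `Cc1ccc(NC(=O)CSc2nncnc2-c2ccccc2Cl)c(Br)c1` has not yet been measured. It differs from compound 3 in one place: 2-bromo-4-methylphenyl in place of 2,4-dichlorophenyl on an amide-type nitrogen. Among the measured compounds shown here, no two measured compounds differ from each other in only one place, so there is no measured step to lean on. The three values all sit within a narrow band, and the change on the amide-type nitrogen is a swap of one aromatic ring for another of the same size and the same count of donors and acceptors. The expected step in this assay is therefore small, and is as likely to fall within the scatter as beyond it, with no clear direction.

On that basis compound 4 is expected to give about 70000 nM in this assay, within a range from 30000 nM to 160000 nM, an estimated step of a 1.4-fold higher number from compound 3 to compound 4 (0.14 log units; within the scatter).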

Compound 4, half-maximal cytotoxic concentration: 45000 nM
For compound 4 the middle estimate is 1.6-fold (0.19 log units) above the measured one; low and high end bracket the measured number.
By their numbers in this assay, from the lowest: compounds 4, 3, 1 and 2 (each within the scatter of the next, the first and the last beyond it).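

Among the compounds shown here, this is the first pair of compounds that differ in one place only, so it gives a direct reading of the group on the amide-type nitrogen. In this assay, putting 2-bromo-4-methylphenyl in place of 2,4-dichlorophenyl gives a 1.1-fold lower number from compound 3 to compound 4 (0.05 log units; within the scatter), so the two compounds cannot be told apart on this read-out. At least for this one pair, a bromine and a methyl group on the ring serve as well as two chlorines, and nothing shown explains why the two rings give such similar numbers.

Still open, as far as these compounds go, is whether a ring on this nitrogen carrying a carboxylic acid or a dimethylamino group, rather than only halogens and methyl, would shift the number beyond the scatter. Also open, from the compounds shown here alone, is whether a longer chain between the amide-type nitrogen and the shared core, which is the same in compound 3 and compound 4, would change the picture.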